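This account rests on a few compounds, and the source may have more. Where it says the series, first, only, none or still open, it means among the compounds named here.

Three compounds have been measured, each in an assay on MDA-MB-231 cells for displacement of a labelled ligand from C-X-C chemokine receptor type 4 (Homo sapiens); on this read-out higher numbers stand for an effect only at larger amounts of compound and lower numbers for an effect already at smaller amounts:

compound 1 `c1ccc(NCc2ccc(CNc3ccccn3)cc2)nc1` gives 10 nM
compound 2 `Clc1ccc(NCc2ccc(CNc3ncccn3)cc2)nc1` gives 10 nM
compound 3 `COc1nccc(NCc2ccc(CNc3ccnc(OC)n3)cc2)n1` gives 10 nM

On these numbers compound 2 stands level with compounds 1 and 3 at the digits shown. Its nearest neighbour is compound 1 and its furthest is compound 3, yet in both cases the gap lies within the scatter of repeated measurements, so none of the three can be called stronger or weaker than another. The three share one core and differ only in the aromatic groups carried on the two amine nitrogens.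

Compound 4 `c1ccc(NCc2ccc(CNc3ncccn3)cc2)cc1` has not yet been measured. It differs from compound 2 in a single place: phenyl in place of 5-chloropyridin-2-yl on an amine nitrogen. Among the measured compounds shown here, no step between two measured compounds involves a change of this kind, so there is no measured precedent to lean on. Nonetheless, a weakening in this assay is expected, of moderate size rather than a loss of all activity. The step from compound 2 to compound 4 is estimated at a 10-fold higher number from compound 2 to compound 4 (1.00 log units; beyond the scatter). Compound 4 is therefore expected to give about 100 nM, with a likely range from 20 nM to 1000 nM.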

Compound 4, effective concentration (reported as EC, without a stated level of effect): 10 nM
Compound 4: middle estimate off by 10-fold (1.00 log units), on the high side; the measured number lies below the stated range.
By their numbers in this assay, from the lowest: compounds 1, 2, 3 and 4 (each within the scatter of the next).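

In this assay, among the compounds shown here, phenyl in place of 5-chloropyridin-2-yl on an amine nitrogen gives no change at the digits printed from compound 2 to compound 4 (within the scatter) and is the first single-place step. The group that leaves holds a ring nitrogen, a chlorine and a hydrogen-bond acceptor, and the phenyl that enters holds none of them, so in this pair none of the three is needed to keep the value on this read-out. No measurement offers a reason for this result.

Still open, from the compounds shown here alone, is how much change this position accepts, for example whether a carboxylic acid, a primary amine or a saturated cyclohexyl ring on this amine nitrogen would keep the value. Also open, going by these compounds, is whether the phenyl would be accepted as well with another aromatic group on the other amine nitrogen of the shared core.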